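Swapping methyl for vinyl on the ring of compound 3

The source may report more compounds than this note shows. Statements on the series, on what has been measured and on what is new or still open speak of the compounds shown alone.

Compound 1 `C=CC1Cc2nc(C)nc(N(C)c3ccc(OC)cc3)c2C1` gives 73.2 nM
Compound 2 `COc1ccc(N(C)c2nc(N)nc3c2CCC3)cc1` gives 16.7 nM
Compound 3 `COc1ccc(N(C)c2nc(N)nc3c2CC(C)C3)cc1` gives 29.9 nM

All three values come from a functional assay on MDA-MB-435 cells (Homo sapiens) for inhibition, read by sulforhodamine B assay, with a stated time of 48 h; a lower number here means a stronger inhibitor, a higher number a weaker inhibitor. Compound 3 lies within the scatter of compound 2 and has a lower number than compound 1, by a gap beyond the scatter.

The next compound is compound 4 `C=CC1Cc2nc(N)nc(N(C)c3ccc(OC)cc3)c2C1`, which has vinyl in place of methyl on a saturated ring carbon. Among the measured compounds shown here, no measured pair shows this exact swap. The closest evidence is the step at the same ring carbon, where methyl replaces hydrogen: a 1.8-fold higher number from compound 2 to compound 3 (0.25 log units; within the scatter). That small step suggests that a modest change at this carbon need not move the number much in this assay. Compound 1 already carries the vinyl but differs from compound 4 elsewhere on the core, so the value of compound 1, 73.2 nM, is only a loose hint, though it tilts the expectation slightly upward.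

The estimated change is small and upward, not beyond the scatter: a 1.3-fold higher number from compound 3 to compound 4 (0.13 log units; within the scatter). Compound 4 is expected to give 40 nM, with an estimated range from 18 nM to 90 nM.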

Compound 4, half-maximal inhibitory concentration: 205 nM
Beside the measured number, compound 4's estimate is 5.1-fold (0.71 log units) below it; measured number outside the range, above it.
By their numbers in this assay, from the lowest: compounds 2 and 3 (each within the scatter of the next); then compound 1; then compound 4.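

In this assay this saturated ring carbon proves far less forgiving than the methyl step suggested: methyl in place of hydrogen stayed within the scatter (a 1.8-fold higher number from compound 2 to compound 3 (0.25 log units; within the scatter)), but vinyl in place of methyl does not (a 6.9-fold higher number from compound 3 to compound 4 (0.84 log units; beyond the scatter)), and the full change from hydrogen to vinyl is large (a 12-fold higher number from compound 2 to compound 4 (1.09 log units; beyond the scatter)). Among the compounds shown here, the result also gives the first reading of a second position, where amino in place of methyl on an aromatic carbon, with the vinyl kept, raises the number (a 2.8-fold higher number from compound 1 to compound 4 (0.45 log units; beyond the scatter)), although this single pair says nothing about how that swap behaves when the ring carbon carries hydrogen or methyl. Nothing measured here accounts for the rise seen with vinyl.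

The compounds shown leave open whether the rise goes with the extra carbon or with the double bond, a question that ethyl at the same ring carbon would address. They also leave open how other groups would fare there, such as hydroxymethyl or an amine.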